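Adding a nitro group: two analogues compared

The source may report more compounds than this note shows. Statements on the series, on what has been measured and on what is new or still open speak of the compounds shown alone.

Measured compounds:
compound 1, `COc1ccc(NC(=O)NCCNS(=O)(=O)c2ccc(-c3ccccc3Oc3ccc([N+](=O)[O-])cc3)s2)cc1`, > 50000 nM
compound 2, `O=S(=O)(c1sccc1-c1ccccc1Oc1ccc(O)c(O)c1)N1CCN(C(=S)Nc2cc(C(F)(F)F)cc(C(F)(F)F)c2)CC1`, 2200 nM
compound 3, `COc1ccc(NC(=O)NCCNS(=O)(=O)c2ccc(-c3ccccc3Oc3ccc([N+](=O)[O-])c([N+](=O)[O-])c3)s2)cc1`, 5400 nM

Compounds 1 and 3 share one core. In a functional assay on HL-60 cells (Homo sapiens) for inhibition, read by CCK-8 assay, with a stated time of 48 h (a lower number here means a stronger inhibitor, a higher number a weaker inhibitor), compound 1 reaches only a limit of the assay, > 50000 nM. Compound 3, by contrast, gives a measurable number, 5400 nM. The difference between them is nitro in place of hydrogen on an aromatic carbon, and it made an at least 9.2-fold lower number from compound 1 to compound 3 (0.96 log units; beyond the scatter). The size of this step is known only as a lower bound because of the limit of > 50000 nM in this assay, at which 1 of the 3 values shown sits.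

Compound 2 rests on a different core; how it differs from compound 1 is not broken down here. In this assay compound 2 gives 2200 nM, the lowest of the two numbers measured.

Compound 4, `O=[N+]([O-])c1ccc(Oc2ccc(O)c(O)c2)c(-c2ccsc2S(=O)(=O)N2CCN(C(=S)Nc3cc(C(F)(F)F)cc(C(F)(F)F)c3)CC2)c1`, is not yet measured. It differs from compound 2 by nitro in place of hydrogen on an aromatic carbon. This is the same kind of change as from compound 1 to compound 3, but the surroundings differ: in compound 3 the new nitro sits ortho to a nitro group, whereas in compound 4 it sits para to a 3,4-dihydroxyphenoxy group.

Since the earlier step is only a bound from a limit and the place differs, a smaller, still favourable step is expected: a 2.4-fold lower number from compound 2 to compound 4 (0.39 log units; beyond the scatter). Compound 4 is accordingly estimated at 900 nM, with a range from 300 nM to 3000 nM.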

Compound 4, half-maximal inhibitory concentration: 8400 nM
The estimate for compound 4 lay 9.3-fold (0.97 log units) below the measured number; measured number outside the range, above it.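

Placed on the core of compound 2, nitro in place of hydrogen on an aromatic carbon gave a 3.8-fold higher number from compound 2 to compound 4 (0.58 log units; beyond the scatter) in this assay, so the change did not keep its direction when carried from one core to the other: the same change on two cores in this assay, an at least 9.2-fold lower number (0.96 log units; beyond the scatter) from compound 1 to compound 3 and a 3.8-fold higher number (0.58 log units; beyond the scatter) from compound 2 to compound 4, at least 35-fold (1.54 log units) apart, beyond the scatter of two such steps. The earlier step is known only as a bound, and the value of compound 1, > 50000 nM, is a limit of the assay: the limit of > 50000 nM in this assay, at which 1 of the 4 values shown sits. This single pair on each core shows that a gain seen on the core of compound 1 could not be assumed for the core of compound 2 in this series, but it does not show what separates the two outcomes, as the two pairs differ both in their cores and in the surroundings of the new nitro group.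

The compounds shown leave open whether an amine or a nitrile at the same aromatic carbon, para to the 3,4-dihydroxyphenoxy group, would shift the number on the core of compound 2 in the same way as nitro. They also leave open how a nitro group would behave on the core of compound 2 at another carbon of that ring, or on a core in which methoxy groups replace the two hydroxyl groups.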